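A methoxy step carried from one core to another

The source may report more compounds than this note shows. Statements on the series, on what has been measured and on what is new or still open speak of the compounds shown alone.

Of the compounds shown here, three have been measured in a functional assay on MCF7 cells (Homo sapiens) for antiproliferative activity, read by sulforhodamine B assay, with a stated time of 48 h; a lower number here means a stronger inhibitor of growth, a higher number a weaker inhibitor of growth. Compound 1 `O=c1oc(CO)cc2ccccc12` gives 89.3 ug/mL in this assay. Compound 2 `COc1ccc2cc(CO)oc(=O)c2c1` carries the change methoxy in place of hydrogen on an aromatic carbon on the core of compound 1, and in this assay compound 2 gives 32.6 ug/mL, which is a 2.7-fold lower number from compound 1 to compound 2 (0.44 log units; beyond the scatter). Compound 3 `O=C1OC(CO)Cc2ccccc21` stands on a different core; the difference between the two cores is not broken down here. In this assay compound 3 gives 0.66 ug/mL, the lowest number of the three, far beyond the scatter from both compound 1 and compound 2.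

Compound 4 `COc1ccc2c(c1)C(=O)OC(CO)C2` has not yet been measured. It differs from compound 3 by methoxy in place of hydrogen on an aromatic carbon. This is the same change as the one from compound 1 to compound 2, at the same place on the ring, and among the compounds shown it occurs twice in all. Within the data shown here, the one measured instance gives a modest move toward a lower number, so a step of about the same size is expected for compound 4, namely a 1.7-fold lower number from compound 3 to compound 4 (0.22 log units; within the scatter), because the step of a 2.7-fold lower number from compound 1 to compound 2 (0.44 log units; beyond the scatter) is the only guide available. Compound 4 is therefore estimated to give 0.4 ug/mL in this assay, with a range from 0.15 ug/mL to 1.5 ug/mL, which allows for the possibility that the change behaves differently on the core of compound 3.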

Compound 4, concentration for 50% growth inhibition: 250 ug/mL
For compound 4 the middle estimate is 630-fold (2.80 log units) below the measured one; the whole stated range lies below it.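

In this assay, methoxy in place of hydrogen on an aromatic carbon does not carry from one core to the other, since on the second core the change gives a 380-fold higher number from compound 3 to compound 4 (2.58 log units; beyond the scatter), a large step in the opposite direction from the modest one on the first core. Set side by side, the two instances of this one change differ in both direction and size: the same change on two cores in this assay, a 2.7-fold lower number (0.44 log units; beyond the scatter) from compound 1 to compound 2 and a 380-fold higher number (2.58 log units; beyond the scatter) from compound 3 to compound 4, 1000-fold (3.02 log units) apart, beyond the scatter of two such steps. This shows that, for these two pairs, the step measured on one core was no guide to the step on the other, but it does not show which difference between the cores is responsible, or why the methoxy group has so large an effect on only one of them, and with one pair per core it gives no general rule for the series.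

The compounds shown leave open whether another group at this place, such as an ethoxy group, a hydroxyl or an amine, would follow the step seen on the core of compound 1 or the one seen on the core of compound 3. They also leave open whether methoxy would split the two cores in the same way with a carboxylic acid in place of the hydroxymethyl group.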